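The compounds below may be only part of what the source reports. "The series", "measured", "known", "first", "only" and "open" are said of these compounds alone.

Measured so far:
compound 1 `CC[C@@H]1C(=O)N(C)c2cnc(-n3ccc4cc(C(=O)NC5CCCC5)ccc43)nc2N1C1CCCC1` — 670 nM
compound 2 `CC[C@@H]1C(=O)N(C)c2cnc(Nc3ccc(S(=O)(=O)NCC(C)C)cc3)nc2N1C1CCCC1` — 750 nM

Both compounds were tested in a functional assay on A549 cells (Homo sapiens) for antiproliferative activity, read by CCK-8 assay, with a stated time of 72 h; on this read-out higher numbers stand for weaker inhibition of growth and lower numbers for stronger inhibition of growth. Compound 1 gives 670 nM there, and compound 2 gives 750 nM; the two numbers lie so close together that the difference is within the usual scatter of repeated measurements, so neither can be called stronger than the other. Compound 3 `CC[C@@H]1C(=O)N(C)c2cnc(-n3ccc4ccccc43)nc2N1C1CCCC1` has not yet been measured in this assay. It differs from compound 1 in one place: hydrogen in place of cyclopentylcarbamoyl on an aromatic carbon. Among the measured compounds shown here, no measured pair in this set reports what such a removal does, so there is no direct step to lean on. Taking away a whole cyclopentylcarbamoyl group with its hydrogen-bond donor and acceptor is a sizeable change, and the expectation is a weakening of growth inhibition, with the step from compound 1 estimated at a 3.0-fold higher number from compound 1 to compound 3 (0.47 log units; beyond the scatter) in this assay. Compound 3 is therefore expected to give about 2000 nM, in a range of 600 nM to 7000 nM.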

Compound 3, concentration for 50% growth inhibition: 57500 nM
Compound 3: middle estimate off by 29-fold (1.46 log units), on the low side; measured number above the stated range.
By their numbers in this assay, from the lowest: compounds 1 and 2 (each within the scatter of the next); then compound 3.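

In this assay, the cyclopentylcarbamoyl group on this aromatic carbon proves to matter greatly: putting hydrogen in its place gives an 86-fold higher number from compound 1 to compound 3 (1.93 log units; beyond the scatter), a large loss of growth inhibition. The earlier compounds shown here could not show this, since compound 1 and compound 2 differ in more than one place and offered no direct reading of any single group. Nothing available here explains why this group counts for so much.

From the compounds shown here alone, what stays open is which part of the group is needed: the amide itself, the cyclopentyl ring, or both. A carboxylic acid or a simple methylamide on the same carbon could begin to separate these, and so could a longer open chain in place of the ring.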